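The source may report more compounds than this note shows. Statements on the series, on what has been measured and on what is new or still open speak of the compounds shown alone.

Compound 1, `CCCOc1ccc(C[C@@H](Cc2ccccc2)C(=O)O)cc1CNC(=O)c1ccc(-c2cccc(F)c2)cc1`, stands at a limit of a physicochemical assay for solubility, read by HPLC, in phosphate buffer, measured as thermodynamic solubility, with a stated time of 48 h, at pH 7.2 (on this read-out lower numbers stand for lower solubility and higher numbers for higher solubility), where compound 1 gives < 1 ug/mL.
Compound 2, `CCCOc1ccc(C[C@@H](Cc2ccccc2)C(=O)O)cc1CNC(=O)c1ccc(-c2cncnc2)cc1`, in this assay gives 190 ug/mL.
Compound 3, `CCCOc1ccc(C[C@@H](Cc2ccccc2)C(=O)O)cc1CNC(=O)c1ccc(-c2ccccc2C)cc1`, stands at a limit of this assay as well, where compound 3 gives < 1 ug/mL.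

Compound 3 thus sits at the low end of what is shown, at the limit of < 1 ug/mL in this assay, at which 2 of the 3 values shown sit. Within the data shown here, the only readable step onto it is an at least 190-fold lower number from compound 2 to compound 3 (2.27 log units; beyond the scatter), a large fall; the step that the two limits leave unreadable from compound 1 to compound 3 cannot be sized, since both of its ends are limits.

Compound 4, `CCCOc1ccc(C[C@@H](Cc2ccccc2)C(=O)O)cc1CNC(=O)c1ccc(-c2ccc(F)cc2)cc1`, differs from compound 3 in one place: 4-fluorophenyl in place of 2-methylphenyl on an aromatic carbon. Among the measured compounds shown here, no measured step swaps one of these two groups for the other. The nearest guide is the pair compound 1 and compound 3, where a 3-fluorophenyl and a 2-methylphenyl both leave the value at the limit; a 4-fluorophenyl is the closer relative of the first. The expected step is therefore a step that the limit leaves unreadable from compound 3 to compound 4, nothing beyond the scatter, with the value most likely again reported only as a limit. Compound 4 is estimated at 0.5 ug/mL, within 0.1 ug/mL to 3 ug/mL.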

Compound 4, solubility: < 1 ug/mL
Compound 4: no number, only a limit; the forecaster's own chance of this, stated with the estimate: 80%; the middle value does not contradict the limit.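

In this assay compound 4 gives < 1 ug/mL, which is a limit and not a number. Putting 4-fluorophenyl in place of pyrimidin-5-yl gives an at least 190-fold lower number from compound 2 to compound 4 (2.27 log units; beyond the scatter), while the steps to compound 4 from the other two compounds at the limit cannot be read, since both ends of each are limits. Compound 1, compound 3 and compound 4 now carry three different rings of carbon only on this aromatic carbon and all stand at the same limit, a pattern that compound 2 goes against: the limit of < 1 ug/mL in this assay, at which 3 of the 4 values shown sit.

On these data alone, how far under the limit these three compounds lie, and whether they differ from one another, stays open. So does whether a pyridin-3-yl, with one ring nitrogen, or a phenyl ring carrying an amine would also lift the value clear of the limit.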